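An Added Group on a Weak Growth Inhibitor

This account rests on a few compounds, and the source may have more. Where it says the series, first, only, none or still open, it means among the compounds named here.

Compound 1 `Cn1cccc1-c1cc(-c2ccc(Br)cc2)[nH]c(=O)c1C#N` was tested in a functional assay on MDA-MB-231 cells (Homo sapiens) for cytotoxicity, read by sulforhodamine B assay, with a stated time of 48 h (a higher number here means a weaker inhibitor of growth, a lower number a stronger inhibitor of growth), where compound 1 gives 83200 nM. Among the three measured compounds, compound 1 is the only one with an actual number. Compound 2 `COc1ccc(-c2cc(-c3cccn3C)c(C#N)c(=O)[nH]2)cc1OC` reaches only the limit of this assay, with compound 2 recorded as > 100000 nM. Compound 3 `COc1ccc(-c2cc(-c3cccs3)[nH]c(=O)c2C#N)cc1` also reaches only the limit, with compound 3 recorded as > 100000 nM. Among the measured compounds shown here, compound 1 therefore stands as the single real value, while the limit of > 100000 nM in this assay, at which 2 of the 3 values shown sit, marks where the other two sit, and whether any of the three differs from another in potency cannot be said.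

Compound 4 `Cn1cccc1-c1cc(-c2ccc(Br)cc2)n(C(=S)Nc2ccc(F)cc2)c(=O)c1C#N` has not yet been measured. It differs from compound 1 by a group of 10 heavy atoms (7 carbon, 1 nitrogen, 1 fluorine, 1 sulfur; one six-membered aromatic ring of carbon only) in place of a hydrogen atom, on an aromatic nitrogen. For the measured compounds named here, no two measured compounds differ in only one place, so there is no measured step to lean on, and this change is unlike any between the measured compounds.

With compound 1 sitting close to the limit and no guide to the direction, only a modest step is expected, in either direction. The expected step is a 1.7-fold lower number from compound 1 to compound 4 (0.22 log units; within the scatter). Compound 4 is estimated at 50000 nM, with a likely range from 12000 nM to 100000 nM, and a fair chance that the assay again reports only a limit.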

Compound 4, concentration for 50% growth inhibition: > 100000 nM
Compound 4: a limit, no number (the forecaster's own chance of this, stated with the estimate: 35%); middle value at least 2.0-fold (0.30 log units) from the limit.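

In this assay compound 4 gives > 100000 nM, which is a limit of the assay and not a number. Among the compounds shown here, none of the earlier compounds carried a change on this aromatic nitrogen, and the step now reads an at least 1.2-fold higher number from compound 1 to compound 4 (0.07 log units; that floor lies within the scatter), so replacing the hydrogen atom with this group of 10 heavy atoms brought no strengthening of growth inhibition that the assay can show, though the floor of the step is too small to establish a real weakening. The change also removes the one real number from any further comparison at this position, leaving the set almost entirely at a ceiling: the limit of > 100000 nM in this assay, at which 3 of the 4 values shown sit.

Going by these compounds, whether a much smaller group on this aromatic nitrogen, such as a methyl or an acetyl group, would leave growth inhibition as it stands in compound 1 remains open. Also open, on these data alone, is whether an amine or a carboxylic acid in place of the bromine of the 4-bromophenyl group would bring the numbers down to where differences between compounds could be read.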